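Benzyl substituent swap: methyl to methoxy

A few compounds are considered here, and "the series" means these few. Any claim that something is new, unique, unknown or untested is made for them only; others in the source may bear on it.

Compound 1 `CCCn1c(=O)c2nc(-c3cnn(Cc4ccccc4C(F)(F)F)c3)[nH]c2n(CCC)c1=O` and compound 2 `CCCn1c(=O)c2nc(-c3cnn(Cc4ccccc4C)c3)[nH]c2n(CCC)c1=O` share one core and differ only in the substituent on the benzyl ring. In an in vitro assay on HEK293 cells for displacement of a labelled ligand from adenosine receptor A2b (Homo sapiens) (on this read-out lower numbers stand for stronger inhibition and higher numbers for weaker inhibition), compound 1 gives 37 nM; in the same run compound 2 gives 33 nM. The step of a 1.1-fold lower number from compound 1 to compound 2 (0.05 log units; within the scatter) shows that exchanging trifluoromethyl for methyl at this aromatic carbon leaves the number essentially unchanged. Compound 2 therefore stands alongside compound 1 on the numbers shown, the two within the scatter of each other, and no ordering between them can be read.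

Compound 3 `CCCn1c(=O)c2nc(-c3cnn(Cc4ccccc4OC)c3)[nH]c2n(CCC)c1=O` carries the change (methoxy in place of methyl on an aromatic carbon). Among the measured compounds shown here, no measured step involves a methoxy here; the only step at this aromatic carbon, a 1.1-fold lower number from compound 1 to compound 2 (0.05 log units; within the scatter), stayed within the scatter although it exchanged groups of quite different make-up. On that basis the expectation for this assay is a step of a 1.1-fold higher number from compound 2 to compound 3 (0.03 log units; within the scatter) with no direction beyond the scatter. The estimate for compound 3 in this assay is 35 nM, with an expected range from 15 nM to 80 nM.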

Compound 3, inhibition constant: 37 nM
Beside the measured number, compound 3's estimate is 1.1-fold (0.02 log units) below it; the range from low to high includes it.
By their numbers in this assay, from the lowest: compounds 2, 1 and 3 (each within the scatter of the next).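

In this assay, methoxy in place of methyl gives a 1.1-fold higher number from compound 2 to compound 3 (0.05 log units; within the scatter), and methoxy in place of trifluoromethyl gives no change at the digits printed from compound 1 to compound 3 (within the scatter). Among the compounds shown here, the earlier compounds offered a single exchange on this aromatic carbon, ortho to a large group; there are now three groups, and methoxy, with its extra heavy atom and one hydrogen-bond acceptor, is the first to bring an oxygen to this place, yet all steps among the three stay within the scatter and no ordering can be read. No outside measurement is available to explain why these three groups read alike.

From the compounds shown here alone, whether the read-out stays flat for a group of another kind at this carbon, such as an amine, a carboxylic acid or a longer alkoxy chain, remains open, as does the reading for a plain benzyl carrying no substituent. Also open, going by these compounds, is whether methyl, methoxy and trifluoromethyl would read alike on another carbon of the same ring, since all three compounds carry their group at this one place.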